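Chain extension from compound 2 to compound 3

This account rests on a few compounds, and the source may have more. Where it says the series, first, only, none or still open, it means among the compounds named here.

Compound 1 `CCC(CCO)n1cnc2c(Cl)nc(F)nc21` and compound 2 `CCCCCCC(CCO)n1cnc2c(Cl)nc(F)nc21` share a core and differ only in a side chain. In a functional assay on SW480 cells (Homo sapiens) for antiproliferative activity, read by MTT assay, with a stated time of 48 h (on this read-out higher numbers stand for weaker inhibition and lower numbers for stronger inhibition), compound 1 gives 19800 nM, while compound 2 gives 12900 nM. Compound 2 stands at the lower end of these two numbers, yet the step of a 1.5-fold lower number from compound 1 to compound 2 (0.19 log units; within the scatter) is within the scatter, so the two are not separable. Compound 3 `CCCCCCCCCC(CCO)n1cnc2c(Cl)nc(F)nc21` carries the change (propyl in place of hydrogen on a saturated chain carbon, seven bonds along the chain from an aromatic nitrogen). For the measured compounds named here, the one comparable step was within the scatter, so the expected step is a 1.3-fold lower number from compound 2 to compound 3 (0.11 log units; within the scatter), with no movement beyond the scatter. Compound 3 is estimated at 10000 nM, within 4000 nM to 25000 nM.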

Compound 3, half-maximal inhibitory concentration: 12500 nM
The estimate for compound 3 lay 1.3-fold (0.10 log units) below the measured number; the range from low to high includes it.
By their numbers in this assay, from the lowest: compounds 3, 2 and 1 (each within the scatter of the next).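

In this assay, propyl in place of hydrogen, seven bonds along the chain from an aromatic nitrogen, gives a 1.0-fold lower number from compound 2 to compound 3 (0.01 log units; within the scatter) and so separates nothing. Over the whole span, heptyl in place of hydrogen, three bonds along the chain from an aromatic nitrogen, gives a 1.6-fold lower number from compound 1 to compound 3 (0.20 log units; within the scatter) and also stays unseparated, so compound 1, compound 2 and compound 3 form one group at this position. Nothing available offers an explanation for this result. Open, as far as these compounds go, is whether an amine or a carboxylic acid on this chain, or a still longer chain, would move the number beyond the scatter.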